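This account rests on a few compounds, and the source may have more. Where it says the series, first, only, none or still open, it means among the compounds named here.

Three compounds have been measured in a functional assay on A549 cells (Homo sapiens) for cytotoxicity; a lower number here means that less compound is needed, a higher number that more compound is needed for the effect:

compound 1 `COC1=C(C)C(=O)/C(=C(O)/C=C/c2cccc(OC)c2)C(=O)C1(C)C` gives 2.8 ug/mL
compound 2 `COC1=C(C)C(=O)/C(=C(O)/C=C/c2ccc(O)cc2)C(=O)C1(C)C` gives 3.1 ug/mL
compound 3 `COC1=C(C)C(=O)/C(=C(O)/C=C/c2ccc(C)cc2)C(=O)C1(C)C` gives 4.3 ug/mL

Compound 3 holds the highest of the three numbers, but its distance from the others is small: the step of a 1.4-fold higher number from compound 2 to compound 3 (0.14 log units; within the scatter) and the step of a 1.5-fold higher number from compound 1 to compound 3 (0.19 log units; within the scatter) both sit inside the scatter, as does the step of a 1.1-fold higher number from compound 1 to compound 2 (0.04 log units; within the scatter). Taken together, the three measured compounds show that swapping the substituent on the aromatic ring attached to the double-bonded chain carbon leaves this assay essentially unchanged.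

Compound 4 `COC1=C(C)C(=O)/C(=C(O)/C=C/c2ccco2)C(=O)C1(C)C` is not yet measured. It differs from compound 3 in one place: furan-2-yl in place of 4-methylphenyl on a double-bonded chain carbon bound to a double-bonded chain carbon. The measured steps all bear on the same position, yet each of them exchanges only a substituent on a six-membered aromatic ring of carbon, whereas here the whole ring is replaced by a five-membered aromatic ring with one hetero atom. Among the compounds with values here, no measured step probes such a replacement, so the data offer only the indication that this position has so far tolerated change without a step beyond the scatter. Compound 4 is therefore expected to show a step of a 1.2-fold higher number from compound 3 to compound 4 (0.07 log units; within the scatter) that stays within the scatter, leaning slightly toward a higher number. The estimate for compound 4 in this assay is 5 ug/mL, with a range from 2.5 ug/mL to 10 ug/mL.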

Compound 4, concentration for half-maximal effect: 10 ug/mL
Compound 4: the middle estimate sits 2.0-fold (0.30 log units) below what was measured; low and high end bracket the measured number.
By their numbers in this assay, from the lowest: compounds 1, 2 and 3 (each within the scatter of the next); then compound 4.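

In this assay, within the data shown here, the place on a double-bonded chain carbon bound to a double-bonded chain carbon proves less tolerant than the earlier compounds suggested. Among these compounds, exchanging the six-membered aromatic ring of carbon for furan-2-yl gives the first steps beyond the scatter, all modest and in the same direction (a 2.3-fold higher number from compound 3 to compound 4 (0.37 log units; beyond the scatter); a 3.2-fold higher number from compound 2 to compound 4 (0.51 log units; beyond the scatter); a 3.6-fold higher number from compound 1 to compound 4 (0.55 log units; beyond the scatter)). The earlier tolerance therefore covers exchanges of substituent on that ring, not this replacement of the ring itself, and nothing measured here explains the change.

The compounds shown leave open whether the ring size or the ring oxygen goes with the higher number. Unsubstituted phenyl, thiophen-2-yl and pyridinyl at this place could begin to separate the two, while a ring carrying an amine or a carboxylic acid remains untested here.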